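Compound 2 and the step to trifluoromethoxy

The source may report more compounds than this note shows. Statements on the series, on what has been measured and on what is new or still open speak of the compounds shown alone.

Compound 1 `Cc1ccc2nc(-c3cccc(C(F)(F)F)c3)[nH]c(=O)c2c1` gives > 50000 nM (a limit)
Compound 2 `COc1cccc(-c2nc3ccc(C)cc3c(=O)[nH]2)c1` gives 32000 nM (a number)

Both compounds were tested in a functional assay on HCT-15 cells (Homo sapiens) for cytotoxicity, read by MTT assay, with a stated time of 2 days; on this read-out higher numbers stand for weaker inhibition and lower numbers for stronger inhibition. Among the measured compounds shown here, compound 2 stands at 32000 nM, the only true number so far. Compound 1 has only a limit, (the limit of > 50000 nM in this assay, at which 1 of the 2 values shown sits), and no number.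

Compound 3 `Cc1ccc2nc(-c3cccc(OC(F)(F)F)c3)[nH]c(=O)c2c1` differs from compound 2 at one place: trifluoromethyl in place of methyl on an oxygen on an aromatic ring, which reads as methoxy to trifluoromethoxy. For the measured compounds named here, the one measured step that bears on this is an at least 1.5-fold lower number from compound 1 to compound 2 (0.19 log units; that floor lies within the scatter), and it also exchanges methoxy and a fluorinated group. Going by these compounds, its true size stays open, so it supports only a small expectation. The expected step is a 1.3-fold higher number from compound 2 to compound 3 (0.10 log units; within the scatter), with no change beyond the scatter anticipated. Compound 3 is estimated at 40000 nM, with an expected range from 20000 nM to 80000 nM in this assay.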

Compound 3, half-maximal inhibitory concentration: > 50000 nM
Compound 3: a limit, no number; the forecaster's own chance of this, stated with the estimate: 45%; middle value at least 1.2-fold (0.09 log units) from the limit.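

Trifluoromethyl in place of methyl on this oxygen gives an at least 1.5-fold higher number from compound 2 to compound 3 (0.19 log units; that floor lies within the scatter), so this change does not yet show a step beyond the scatter. Compound 1 and compound 3 are both limits, so the step between them cannot be read and trifluoromethyl and trifluoromethoxy on the aromatic carbon cannot be told apart. Among the three compounds in this assay, only compound 2, with its methoxy, has a true number, and the two compounds with fluorinated groups end at the same limit: the limit of > 50000 nM in this assay, at which 2 of the 3 values shown sit.

The compounds shown leave open what true values lie behind those two limits, and so how large the step from methoxy to trifluoromethoxy really is. They also leave open whether an ethyl group or a longer chain on this oxygen, or an amine in place of the oxygen, would give a true number in this assay.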